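Weighing a Benzyloxy Group on the Shared Core

A few compounds are considered here, and "the series" means these few. Any claim that something is new, unique, unknown or untested is made for them only; others in the source may bear on it.

Of the compounds shown here, two have so far been measured in a functional assay on HeLa cells (Homo sapiens) for cytotoxicity, read by MTT assay, with a stated time of 24 h; a lower number here means a stronger inhibitor, a higher number a weaker inhibitor. Compound 1 `Cc1cc(O)c(C(=O)/C=C/c2ccc(Cl)cc2)c(-c2ccccc2)c1C(=O)/C=C/c1ccc(Cl)cc1` gives 30000 nM in this assay, the higher of the two numbers. Compound 2 `Cc1cc(O)c(C(=O)/C=C/c2cccc(Cl)c2)c(-c2ccccc2)c1C(=O)/C=C/c1cccc(Cl)c1` gives 22000 nM in this assay; its value and that of compound 1 lie within the scatter of each other, so the two cannot be told apart. Within the data shown here, no step between measured compounds that differ in a single place is available to guide an expectation.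

Compound 3 `Cc1cc(O)c(C(=O)/C=C/c2ccc(Cl)cc2)c(-c2ccc(OCc3ccccc3)cc2)c1C(=O)/C=C/c1ccc(Cl)cc1` has not yet been measured. It differs from compound 1 by benzyloxy in place of hydrogen on an aromatic carbon. Among the measured compounds shown here, with no comparable step among the measured compounds, the direction of any change in this assay is open, and the account expects a step no larger than the scatter, in either direction. The expected step of a 1.2-fold lower number from compound 1 to compound 3 (0.08 log units; within the scatter) is accordingly small. Compound 3 is estimated at 25000 nM in this assay, with a range from 8000 nM to 70000 nM.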

Compound 3, half-maximal inhibitory concentration: "not active" (no number reported)
Nothing numeric was reported for compound 3; there is nothing to compare the estimate with.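

In this assay, among these compounds, compound 3 is reported as not active, with no number, so no step from compound 1 to compound 3 can be read. The compounds shown leave open how far benzyloxy in place of hydrogen shifts the value. No measured evidence bears on this result.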